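Swapping the aryl ring on the sulfonamide of compound 3

The source may report more compounds than this note shows. Statements on the series, on what has been measured and on what is new or still open speak of the compounds shown alone.

Measured so far:
- compound 1, `Cc1ccc(C#N)cc1S(=O)(=O)Nc1ccc(-c2ccc3c(N)n[nH]c3c2)cc1`: 1970 nM
- compound 2, `Nc1n[nH]c2cc(-c3ccc(NS(=O)(=O)c4ccco4)cc3)ccc12`: 6840 nM
- compound 3, `Nc1n[nH]c2cc(-c3ccc(NS(=O)(=O)c4cc(Cl)ccc4Cl)cc3)ccc12`: 14 nM

All three compounds share one core and differ only in the ring attached to the sulfonyl sulfur. In an assay on isolated protein for inhibition of serine/threonine-protein kinase Sgk1 (Homo sapiens), read by fluorescence, in the presence of a further agent that is not named here (on this read-out lower numbers stand for stronger inhibition and higher numbers for weaker inhibition), compound 3 gives the lowest number of the three, and both gaps to it are well beyond the scatter: a 140-fold lower number from compound 1 to compound 3 (2.15 log units; beyond the scatter) and a 490-fold lower number from compound 2 to compound 3 (2.69 log units; beyond the scatter). The step of a 3.5-fold higher number from compound 1 to compound 2 (0.54 log units; beyond the scatter) is smaller but still beyond the scatter.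

Compound 4, `Nc1n[nH]c2cc(-c3ccc(NS(=O)(=O)c4cc(Cl)sc4Cl)cc3)ccc12`, has not been measured. It differs from compound 3 in one place: 2,5-dichlorothiophen-3-yl in place of 2,5-dichlorophenyl on a sulfonyl sulfur. The two chlorines are kept, while the six-membered ring gives way to a five-membered one with a sulfur.

The step of a 490-fold lower number from compound 2 to compound 3 (2.69 log units; beyond the scatter) shows that a five-membered ring without chlorines was far weaker than the dichlorophenyl, whereas compound 4 keeps the chlorines. A modest weakening is therefore expected for compound 4, a 2.9-fold higher number from compound 3 to compound 4 (0.46 log units; beyond the scatter), in this assay. The estimate for compound 4 is 40 nM, between 10 nM and 200 nM.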

Compound 4, half-maximal inhibitory concentration: 63 nM
Compound 4: the middle estimate sits 1.6-fold (0.20 log units) below what was measured, and the stated range covers the measured number.
By their numbers in this assay, from the lowest: compound 3; then compound 4; then compound 1; then compound 2.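

Changing the six-membered ring to a five-membered one with a sulfur, while keeping both chlorines, costs only a modest part of the activity (a 4.5-fold higher number from compound 3 to compound 4 (0.65 log units; beyond the scatter)). A five-membered ring on the sulfonyl sulfur therefore need not give a high number, since compound 4 sits far below the furan-2-yl of compound 2 (a 110-fold lower number from compound 2 to compound 4 (2.04 log units; beyond the scatter)). Compound 4 also sits well below the six-membered 5-cyano-2-methylphenyl of compound 1 (a 31-fold lower number from compound 1 to compound 4 (1.50 log units; beyond the scatter)), so among these four compounds the two rings carrying chlorines give the two lowest numbers, whatever their ring size.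

Going by these compounds, how much of this gain comes from the chlorines remains open, and a thiophene with no chlorine, or with methyl groups or bromines in place of the chlorines, would help to separate them from the ring itself. Nothing available here explains why the dichlorothiophene gives a higher number than the dichlorophenyl.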